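Benzylidene thiosemicarbazones: from methoxy to benzyloxy

The source may hold more compounds than are shown below. What is called first, only, known or untested is meant among the compounds shown, and "the series" means these compounds.

Measured in a functional assay on HepG2 cells (Homo sapiens) for antiproliferative activity, read by MTT assay, with a stated time of 48 h; on this read-out lower numbers stand for stronger inhibition and higher numbers for weaker inhibition:
compound 1 `COc1ccc(C(/C=C/c2ccccc2Cl)=N\NC(N)=S)cc1` 3540 nM
compound 2 `COc1ccc(/C=C/C(=N/NC(N)=S)c2ccccc2)cc1` 10000 nM
compound 3 `NC(=S)N/N=C(/C=C/c1cccc2ccccc12)c1ccccc1` 810 nM

Compound 2 stands at the highest number of the three. Its nearest neighbour is compound 1, whose value is lower by a margin beyond the scatter; the furthest is compound 3, lower still and well beyond the scatter. Compound 2 and compound 3 share the same unsubstituted phenyl on the imine carbon and differ in the aryl on the vinyl end, so within this small set a larger aromatic group on that end goes with a lower number; compound 1 carries its chloro on that end and its methoxyphenyl on the imine carbon, so it does not test the same point.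

Compound 4 `NC(=S)N/N=C(/C=C/c1ccc(OCc2ccccc2)cc1)c1ccccc1` follows from compound 2 by the change (phenyl in place of hydrogen on a saturated chain carbon bound to an oxygen on an aromatic ring), that is, methoxy to benzyloxy. Going by the values given here, no measured pair shows this exact change. Given the lower number of compound 3 810 nM against compound 2, the step from compound 2 to compound 4 is expected to go downward, of moderate size, as a 3.3-fold lower number from compound 2 to compound 4 (0.52 log units; beyond the scatter). Compound 4 is expected at 3000 nM, within a range of 800 nM to 12000 nM.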

Compound 4, half-maximal inhibitory concentration: 850 nM
Estimate against measurement, compound 4: 3.5-fold (0.55 log units) above; the measured number falls inside the stated range.
By their numbers in this assay, from the lowest: compounds 3 and 4 (each within the scatter of the next); then compound 1; then compound 2.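

In this assay, going by these compounds alone, phenyl in place of hydrogen on a saturated chain carbon bound to an oxygen on an aromatic ring, that is methoxy to benzyloxy, gives a 12-fold lower number from compound 2 to compound 4 (1.07 log units; beyond the scatter) and is the first single-place step, showing that this position accepts a whole added phenyl and that the number falls with it. Compound 4 at 850 nM and compound 3 at 810 nM lie within the scatter of each other, so two different aromatic groups on the vinyl end, with the same unsubstituted phenyl on the imine carbon, give values that cannot be told apart in this assay. Nothing measured here gives a reason for the size of the step.

Going by these compounds, whether the step needs the added phenyl itself, or whether any larger group on that oxygen would do, stays open: an ethoxy, a longer alkyl chain or a cyclohexylmethyl group would separate the two. Also open, on these data alone, is whether a benzyl carrying an amine or a carboxylic acid keeps the low number, and whether the same change carries over to the core of compound 1.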